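Swapping Trifluoromethyl for Tert-Butyl on a Nitrile Phenol Core

This account rests on a few compounds, and the source may have more. Where it says the series, first, only, none or still open, it means among the compounds named here.

Of the compounds shown here, three sharing one core have been measured in an assay on isolated protein for inhibition of solute carrier family 22 member 12 (Homo sapiens), tested at 3 uM; on this read-out higher numbers stand for more inhibition at the one concentration tested (going by the name of the read-out) and lower numbers for less inhibition. Compound 1 `CC(C)(C)c1cc(C(=O)N2CC=CC2)cc(C#N)c1O` gives 92%, compound 2 `CC(C)(C)c1cc(C(=O)N2CCCC2)cc(C#N)c1O` gives 84%, and compound 3 `N#Cc1cc(C(=O)N2CCC2)cc(C(F)(F)F)c1O` gives 75%. Among the compounds with values here, the only step between compounds that differ in a single place, a number 8 percentage points lower from compound 1 to compound 2 (within the scatter), exchanges one five-membered ring for another on the carbonyl carbon. Compound 3 stands lowest of the three numbers: its value sits close to that of compound 2, so the two cannot be told apart, while compound 1 lies clearly higher.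

Compound 4 `CC(C)(C)c1cc(C(=O)N2CCC2)cc(C#N)c1O` has not yet been measured. It differs from compound 3 in one place: tert-butyl in place of trifluoromethyl on an aromatic carbon. Within the data shown here, no measured step touches this position, so the size of the change can only be judged indirectly. Compound 1 and compound 2 both carry tert-butyl and both give higher numbers than compound 3, but each also differs from compound 3 in the ring on the carbonyl carbon, so their values do not isolate the change. Compound 4 is therefore expected to show a step of a number 8 percentage points higher from compound 3 to compound 4 (within the scatter), upward, though a step within the scatter remains possible. The estimate for compound 4 in this assay is 83%, between 68% and 95%.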

Compound 4, a percentage reported as inhibition, at one concentration (the size of the read-out at that concentration, not a potency): 71%
Estimate against measurement, compound 4: 12 percentage points above, and the stated range covers the measured number.
By their numbers in this assay, from the lowest: compounds 4, 3, 2 and 1 (each within the scatter of the next, the first and the last beyond it).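

In this assay, placing tert-butyl where trifluoromethyl stood, on the aromatic carbon ortho to a hydroxy group, gives a number 4 percentage points lower from compound 3 to compound 4 (within the scatter), so with the (azetidin-1-yl)carbonyl group kept in place, these two groups cannot be told apart at this position. With tert-butyl held constant, the group on the carbonyl carbon can now be read on its own: azetidin-1-yl in place of pyrrolidin-1-yl gives a number 13 percentage points lower from compound 2 to compound 4 (beyond the scatter), and the same four-membered ring in place of the five-membered ring of compound 1 gives a number 21 percentage points lower from compound 1 to compound 4 (beyond the scatter), so the steps beyond the usual scatter lie on the carbonyl carbon, not on the aromatic carbon. Nothing available explains why either position behaves as it does.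

Going by these compounds, it remains open whether trifluoromethyl and tert-butyl would still be indistinguishable with pyrrolidin-1-yl on the carbonyl carbon, since a reading at one concentration shows no potency and a small difference could appear in another setting. Also open, on these data alone, is how a methyl group or a chlorine atom would fare on the aromatic carbon, and how an open-chain diethylamino group would compare on the carbonyl carbon.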